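Carbonyl substituent change at the piperidine amide in this series

This account rests on a few compounds, and the source may have more. Where it says the series, first, only, none or still open, it means among the compounds named here.

For the measured compounds named here, compound 2 `Cc1nc(S(C)(=O)=O)ccc1Oc1ncnc(OC2CCN(C(=O)C(C)(C)F)CC2)c1F` gives 296 nM in a functional assay on isolated protein for inhibition of Glucose-dependent insulinotropic receptor (Rattus norvegicus), read by HTRF and cAMP accumulation (a lower number here means that less compound is needed, a higher number that more compound is needed for the effect), the highest of the two numbers so far; the nearest is compound 1 `Cc1nc(S(C)(=O)=O)ccc1Oc1ncnc(OC2CCN(C(=O)SC(C)C)CC2)c1F`, which in this assay gives 41.3 nM. Going by the values given here, the one measured step at this carbonyl carbon, a 7.2-fold higher number from compound 1 to compound 2 (0.86 log units; beyond the scatter), involved a different group leaving than the one now in question, so it is only indirectly relevant. Compound 3 `CCc1cnc(C(=O)N2CCC(Oc3ncnc(Oc4ccc(S(C)(=O)=O)nc4C)c3F)CC2)nc1` carries the change (5-ethylpyrimidin-2-yl in place of 1-fluoro-1-methylethyl on a carbonyl carbon). Among the compounds with values here, the only guidance is that the carbonyl substituent does move the number in this assay by a modest amount in the measured pair, and the direction for an aromatic ring here is not settled by any measured compound. The step is expected to go downward, roughly back toward the level of compound 1, but with wide uncertainty: a 2.5-fold lower number from compound 2 to compound 3 (0.39 log units; beyond the scatter) is the estimate for the step from compound 2 to compound 3. Compound 3 is therefore estimated at 120 nM in this assay, within a range of 30 nM to 500 nM.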

Compound 3, half-maximal effective concentration: 40.8 nM
Compound 3: middle estimate off by 2.9-fold (0.47 log units), on the high side; the range from low to high includes it.
By their numbers in this assay, from the lowest: compounds 3 and 1 (each within the scatter of the next); then compound 2.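

In this assay, the carbonyl carbon on the ring amide nitrogen tolerates an aromatic ring: 5-ethylpyrimidin-2-yl in place of 1-fluoro-1-methylethyl gives a 7.3-fold lower number from compound 2 to compound 3 (0.86 log units; beyond the scatter) and so exceeds the scatter. The same ring in place of isopropylsulfanyl gives a 1.0-fold lower number from compound 1 to compound 3 (0.01 log units; within the scatter), which leaves compound 1 and compound 3 on one level despite their very different carbonyl substituents, so among these three compounds the sulfur-linked group is not required to reach that level, and compound 2 alone stands apart with the higher number. Nothing available bears on the reason for these differences.

The three compounds do not separate the contribution of the ethyl group from that of the ring itself or its two nitrogens, so a plain phenyl ring, an unsubstituted pyrimidin-2-yl or a longer chain in place of the ethyl group would each be informative. Also open, on these data alone, is whether a simple amine on the carbonyl carbon, giving a urea, would fall with compound 1 and compound 3 or with compound 2.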